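This account rests on a few compounds, and the source may have more. Where it says the series, first, only, none or still open, it means among the compounds named here.

Compound 1 `CCC1CCN(c2cc(C(F)(F)F)ccc2CNC(=O)C(C)c2ccc(NS(C)(=O)=O)c(F)c2)CC1` gives 0.7 nM.
Compound 2 `CC(C(=O)NCc1ccc(C(F)(F)F)cc1N1CCC(c2ccc(F)cc2)CC1)c1ccc(NS(C)(=O)=O)c(F)c1` gives 0.9 nM.

In an assay on CHO cells for antagonist activity at transient receptor potential cation channel subfamily V member 1 (Homo sapiens), read by FLIPR (a higher number here means a weaker inhibitor, a lower number a stronger inhibitor), compound 1 stands at the lowest of the two numbers, yet the step of a 1.3-fold higher number from compound 1 to compound 2 (0.11 log units; within the scatter) is within the scatter, so the two compounds cannot be ranked. Compound 3 `CC(C(=O)NCc1ccc(C(F)(F)F)cc1OC1CCCCC1)c1ccc(NS(C)(=O)=O)c(F)c1` differs from compound 1 in one place: cyclohexyloxy in place of 4-ethylpiperidin-1-yl on an aromatic carbon. Among the measured compounds shown here, no measured step touches this part of the molecule in the same way, so the expectation rests on little. Compound 3 is expected at 3 nM (range 0.7 nM to 15 nM), a modest move toward a weaker inhibitor, a 4.3-fold higher number from compound 1 to compound 3 (0.63 log units; beyond the scatter).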

Compound 3, inhibition constant: 0.7 nM
Compound 3: middle estimate off by 4.3-fold (0.63 log units), on the high side; low and high end bracket the measured number.
By their numbers in this assay, from the lowest: compounds 1, 3 and 2 (each within the scatter of the next).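

The change from 4-ethylpiperidin-1-yl to cyclohexyloxy gives no change at the digits printed from compound 1 to compound 3 (within the scatter) in this assay, so a carbon-only ring attached through oxygen serves at this aromatic carbon as well as a ring attached through its nitrogen. The earlier step changed only the ethyl group on the saturated ring, leaving the nitrogen attachment in place. Going by these compounds, whether cyclopentyloxy, an open chain such as butoxy, or an amine such as cyclohexylamino would also hold the number at this carbon remains open. No evidence here explains why these two groups match.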